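Chloro for hydrogen on the shared core: compound 1 to compound 4

The source may report more compounds than this note shows. Statements on the series, on what has been measured and on what is new or still open speak of the compounds shown alone.

Measured so far in a functional assay on ACHN cells (Homo sapiens) for cytotoxicity, read by sulforhodamine B assay, with a stated time of 48 h; a lower number here means a stronger inhibitor of growth, a higher number a weaker inhibitor of growth:
compound 1 `ClCc1cccc(Cn2cnc3ncnc(Cl)c32)c1` gives 3540 nM
compound 2 `ClCc1cccc(Cn2cnc3c(Cl)nc(Cl)nc32)c1` gives 3710 nM
compound 3 `ClCc1ccc(Cn2cnc3c(Cl)nc(Cl)nc32)cc1` gives 5250 nM

Compound 1 has the lowest of the three numbers, yet compound 2 and compound 3 both lie within the scatter of it, so no order among the three can be claimed.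

Compound 4 `ClCc1cccc(Cn2cnc3nc(Cl)nc(Cl)c32)c1` differs from compound 1 by chloro in place of hydrogen on an aromatic carbon, sitting between two ring nitrogen atoms, meta to a chloro group, meta to a fused ring and para to a fused ring. Among the measured compounds shown here, no pair among the measured compounds isolates this change. Compound 2 and compound 3 carry two chloro groups on their cores and sit in the same region as compound 1, which argues against a large step in this assay. The expected step from compound 1 to compound 4 is therefore a 1.0-fold higher number from compound 1 to compound 4 (0.01 log units; within the scatter), none beyond the scatter. Compound 4 is estimated at 3600 nM, with a range of 1800 nM to 7500 nM.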

Compound 4, concentration for total growth inhibition: 2340 nM
Estimate against measurement, compound 4: 1.5-fold (0.19 log units) above, within the range that was stated.
By their numbers in this assay, from the lowest: compounds 4, 1, 2 and 3 (each within the scatter of the next, the first and the last beyond it).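

In this assay, chloro in place of hydrogen on an aromatic carbon, between two ring nitrogen atoms, gives a 1.5-fold lower number from compound 1 to compound 4 (0.18 log units; within the scatter). Among the compounds shown here, this is the first pair that isolates this change, and it shows that the position carries a chloro group with no step beyond the scatter. No measurement bears on why the number stays in this region.

As far as these compounds go, whether an amine or a methoxy group at this position would move the number beyond the scatter remains open.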